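A few compounds are considered here, and "the series" means these few. Any claim that something is new, unique, unknown or untested is made for them only; others in the source may bear on it.

Measured so far in a functional assay on MKN-45 cells (Homo sapiens) for antiproliferative activity, with a stated time of 72 h; on this read-out higher numbers stand for weaker inhibition and lower numbers for stronger inhibition:
- compound 1 `Nc1ncnc2[nH]cc(-c3ccc(NC(=O)c4cn(CC5CCOCC5)cc(-c5ccc(F)cc5)c4=O)cc3)c12` gives 77.9 nM
- compound 2 `Cn1cc(-c2ccc(NC(=O)c3cn(CC4CCOCC4)cc(-c4ccc(F)cc4F)c3=O)cc2)c2c(N)ncnc21` gives 501 nM

Compound 2 holds the higher of these two numbers, and its gap to compound 1 lies beyond the scatter. Compound 3 `Cn1cc(-c2ccc(NC(=O)c3cn(CC4CCOCC4)cc(-c4ccc(Cl)cc4)c3=O)cc2)c2c(N)ncnc21` is not yet measured. It departs from compound 2 at one place: 4-chlorophenyl in place of 2,4-difluorophenyl on an aromatic carbon. Here 4-chlorophenyl stands in place of 2,4-difluorophenyl on an aromatic carbon of a six-membered aromatic ring with 1 nitrogen.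

Among the measured compounds shown here, no step between measured compounds that differ in one place is available, so this exchange has no direct precedent. For the measured compounds named here, the only guide is the spread of the two values, from compound 1 at 77.9 nM to compound 2 at 501 nM. The result for compound 3 is expected to fall near or within that spread, and the uncertainty remains wide. In this assay the expected change is small, leaning towards a lower number but not beyond the scatter: the estimated step is a 1.7-fold lower number from compound 2 to compound 3 (0.22 log units; within the scatter). In this assay the estimated value for compound 3 is 300 nM, with an expected range from 110 nM to 800 nM.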

Compound 3, half-maximal inhibitory concentration: 347 nM
The estimate for compound 3 lay 1.2-fold (0.06 log units) below the measured number; measured number inside the range.
By their numbers in this assay, from the lowest: compound 1; then compounds 3 and 2 (each within the scatter of the next).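

In this assay, among the compounds shown here, the exchange of 2,4-difluorophenyl for 4-chlorophenyl on an aromatic carbon of the six-membered aromatic ring with 1 nitrogen gives a 1.4-fold lower number from compound 2 to compound 3 (0.16 log units; within the scatter), the first step that isolates this position. At this position, then, this read-out does not separate the two groups, although the exchange replaces two fluorine atoms with one chlorine atom and goes from 8 heavy atoms to 7. Nothing measured here bears on why the two groups read alike.

Still open, going by these compounds, is how an unsubstituted phenyl, a 4-methoxyphenyl, a pyridyl ring or a small amine on the same carbon would read in this assay, since the two groups compared here are both halogenated phenyl rings. Compound 1, at 77.9 nM, differs from compound 2 and from compound 3 in more than one place, so the values shown cannot divide its distance from them between the aryl group and the methyl group on the shared core.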